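A few compounds are considered here, and "the series" means these few. Any claim that something is new, unique, unknown or untested is made for them only; others in the source may bear on it.

In a functional assay on HL-60 cells (Homo sapiens) for antiproliferative activity, read by XTT assay, with a stated time of 72 h (a higher number here means a weaker inhibitor, a lower number a stronger inhibitor), compound 3 (`COc1nc(N)nc2c1c(-c1ccccc1)cn2[C@@H]1O[C@H](CO)[C@@H](O)[C@H]1O`) stands only at a limit, > 20000 nM. Compound 2 (`COc1nc(N)nc2c1c(-c1ccoc1)cn2[C@@H]1O[C@H](CO)[C@@H](O)[C@H]1O`) is also only a limit, > 20000 nM. Compound 2 and compound 3 therefore both rest on (the limit of > 20000 nM in this assay, at which 2 of the 3 values shown sit), and neither has a measured number.

Compound 4 (`C#Cc1cn([C@@H]2O[C@H](CO)[C@@H](O)[C@H]2O)c2nc(N)nc(OC)c12`) carries ethynyl in place of phenyl on an aromatic carbon, on the five-membered aromatic ring of the shared core: ethynyl in place of phenyl on an aromatic carbon.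

Within the data shown here, the one measured step, a step that the two limits leave unreadable from compound 2 to compound 3, gives no size to carry over, and it concerns a swap between furan-3-yl and phenyl rather than ethynyl. Among the measured compounds shown here, the only number comes from compound 1 (`C#Cc1cn([C@@H]2O[C@H](CO)[C@@H](O)[C@H]2O)c2ncnc(OC)c12`), which also carries ethynyl and gives 190 nM in this assay. That single value is the basis for expecting a gain in potency on moving to ethynyl, though compound 1 is one compound and sets no pattern.

For the measured compounds named here, no measured step isolates this change, so the expectation stays loose and compound 4 may yet remain at the limit. The expected change is an at least 6.6-fold lower number from compound 3 to compound 4 (0.82 log units; beyond the scatter), towards stronger inhibition. Compound 4 is estimated at 3000 nM, with an expected range of 300 nM to 20000 nM.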

Compound 4, half-maximal inhibitory concentration: > 20000 nM
Compound 4: only a limit was reported (the forecaster's own chance of this, stated with the estimate: 30%); middle value at least 6.6-fold (0.82 log units) from the limit.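

In this assay compound 4 is reported only as a limit, > 20000 nM, not as a number. Ethynyl on this aromatic carbon therefore does not by itself bring the amino-bearing core to a measurable value, and this swap for phenyl gives no readable gain. The steps among compound 2, compound 3 and compound 4 cannot be read, as all three share one limit: the limit of > 20000 nM in this assay, at which 3 of the 4 values shown sit.

The readable information lies in the other place of change: with ethynyl held constant, amino in place of hydrogen on an aromatic carbon gives an at least 100-fold higher number from compound 1 to compound 4 (2.02 log units; beyond the scatter), so in this single pair the amino group goes with the loss of measurable activity and ethynyl alone does not carry it.

As far as these compounds go, whether phenyl or furan-3-yl on the core of compound 1 would give a number stays open, so the effect of ethynyl at this position still has no measured size. Also open, from the compounds shown here alone, is how a methyl group or a dimethylamino group in place of that amino would read in this assay, and so whether the large step belongs to amino specifically or to any group at that carbon.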